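The source may hold more compounds than are shown below. What is called first, only, known or untested is meant among the compounds shown, and "the series" means these compounds.

The measured compounds: compound 1 `O=C(c1ccc(F)c(F)c1)N1CC(c2nc(-c3cccc(F)c3)no2)C1`, compound 2 `O=C(c1ccc(F)cc1)N1CC(c2nc(-c3cccc(Cl)c3)no2)C1`, compound 3 `CC1CCN(C(=O)N2CC(c3nc(-c4cccc(Cl)c4)no3)C2)C1`.

In an assay on HEK293 cells for negative allosteric modulation of metabotropic glutamate receptor 5 (Homo sapiens), read by FLIPR (a lower number here means a stronger inhibitor, a higher number a weaker inhibitor), compound 1 gives > 10000 nM, which is a limit of the assay rather than a number. Compound 2 gives 4000 nM in this assay. Compound 3 gives > 10000 nM in this assay, again a limit and not a number. Compound 3 thus sits at the limit of > 10000 nM in this assay, at which 2 of the 3 values shown sit. For the measured compounds named here, the one step measured between compounds that differ in a single place, an at least 2.5-fold higher number from compound 2 to compound 3 (0.39 log units; beyond the scatter), already carried the number up to that limit.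

Compound 4 `COC1CCCN(C(=O)N2CC(c3nc(-c4cccc(Cl)c4)no3)C2)C1` differs from compound 3 by 3-methoxypiperidin-1-yl in place of 3-methylpyrrolidin-1-yl on a carbonyl carbon. Going by the values given here, no measured step exchanges one saturated ring amine for another, so the step from compound 3 to compound 4 has no direct counterpart among the measured compounds; the only comparison available, an at least 2.5-fold higher number from compound 2 to compound 3 (0.39 log units; beyond the scatter), shows that a ring amine on the carbonyl carbon went with a weaker inhibitor than an aryl group there. Compound 4 is therefore expected to remain at or near the limit, with the estimated step that the limit leaves unreadable from compound 3 to compound 4 lying within the scatter. The estimate for compound 4 is 15000 nM, between 5000 nM and 50000 nM.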

Compound 4, half-maximal inhibitory concentration: 1830 nM
Beside the measured number, compound 4's estimate is 8.2-fold (0.91 log units) above it; the whole stated range lies above it.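

On the carbonyl carbon, a saturated ring amine does not by itself mean a weaker inhibitor in this assay: 3-methoxypiperidin-1-yl gives an at least 5.4-fold lower number from compound 3 to compound 4 (0.73 log units; beyond the scatter), and in place of 4-fluorophenyl it gives a 2.2-fold lower number from compound 2 to compound 4 (0.34 log units; beyond the scatter). The earlier drop from the aryl group to a ring amine therefore holds for compound 3 but not for compound 4, so the identity of the ring amine matters at this position. The full size of the first step cannot be read because compound 3 has only a limit of the assay, not a number: the limit of > 10000 nM in this assay, at which 2 of the 4 values shown sit.

The change alters ring size and swaps methyl for methoxy at once, so the compounds shown do not separate the two. 3-Methylpiperidin-1-yl and 3-methoxypyrrolidin-1-yl would each isolate one of these changes, and whether the ring is needed at all stays open for an open-chain amine such as dimethylamino.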